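The source may report more compounds than this note shows. Statements on the series, on what has been measured and on what is new or still open speak of the compounds shown alone.

Compound 2 `COc1ccc(C(=O)/C=C/c2cc(-c3cc(OC)c(OC)c(OC)c3)n[nH]2)cc1OC` is the stronger of the two compounds measured in a functional assay on SF-539 cells (Homo sapiens) for cytotoxicity, read by sulforhodamine B assay, with a stated time of 48 h, tested at 100 uM; a lower number here means a stronger effect, a higher number a weaker effect of the compound at the concentration tested: compound 2 gives -96%, the lowest of the two numbers, while compound 1 `COc1cc(-c2cc(/C=C/C(=O)c3ccc(Cl)c(Cl)c3)[nH]n2)cc(OC)c1OC` gives -74%. Among the measured compounds shown here, the one step on record, a number 22 percentage points lower from compound 1 to compound 2 (beyond the scatter), is a modest change beyond the scatter and concerns the aryl on the carbonyl carbon. Compound 3 `COc1cc(C(=O)/C=C/c2cc(-c3cc(OC)c(OC)c(OC)c3)n[nH]2)cc(OC)c1OC` keeps that dimethoxy pattern and adds a further group: methoxy in place of hydrogen on an aromatic carbon, ortho to a methoxy group and meta to a methoxy group. For the measured compounds named here, no measured step covers a hydrogen to methoxy exchange on this ring; the step from compound 1 to compound 2 is a different exchange and gives no direction for it. Compound 3 is therefore expected to stay close to compound 2, with a number 3 percentage points higher from compound 2 to compound 3 (within the scatter) expected to lie within the scatter. The estimate for compound 3 in this assay is -93%, expected between -100% and -75%.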

Compound 3, a percentage reported as activity, at one concentration (the size of the read-out at that concentration, not a potency): -99%
Estimate against measurement, compound 3: 6 percentage points above; low and high end bracket the measured number.
By their numbers in this assay, from the lowest: compounds 3 and 2 (each within the scatter of the next); then compound 1.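

In this assay, methoxy in place of hydrogen on an aromatic carbon, ortho to a methoxy group and meta to a methoxy group, gives a number 3 percentage points lower from compound 2 to compound 3 (within the scatter), so compounds 2 and 3 cannot be told apart and this ring position accepts the added methoxy. The earlier step, a number 22 percentage points lower from compound 1 to compound 2 (beyond the scatter), exchanged 3,4-dichlorophenyl for 3,4-dimethoxyphenyl and said nothing about adding a group to the 3,4-dimethoxyphenyl ring. No measurement at hand bears on why the read-out holds with the added methoxy.

The compounds shown leave open whether an amine, a carboxylic acid or a longer chain such as ethoxy would be accepted at this position in the same way. A read-out at one concentration also leaves open whether compounds 2 and 3 would separate in potency.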